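The source may hold more compounds than are shown below. What is called first, only, known or untested is meant among the compounds shown, and "the series" means these compounds.

Working notes on the series. Compound 1 (`O=C(Nc1cccc(F)c1)c1cc(=O)[nH]c2cc(-c3ccccc3)ccc12`) gives > 20000 nM in a functional assay on KYSE-70 cells for antiproliferative activity against KYSE-70 cell line (Homo sapiens), read by MTT assay, with a stated time of 72 h (a lower number here means a stronger inhibitor, a higher number a weaker inhibitor), and this is a limit, not a number. Compound 2 (`Cc1ccc(-c2ccc3c(C(=O)Nc4cccc(F)c4)cc(=O)[nH]c3c2)cc1`) gives > 20000 nM as a limit too. Compound 3 (`Nc1ccc(-c2ccc3c(C(=O)Nc4cccc(F)c4)cc(=O)[nH]c3c2)cc1`) gives > 20000 nM and that also is only a limit. Compound 3 therefore has no number of its own and stands with the other two at one reading (the limit of > 20000 nM in this assay, at which 3 of the 3 values shown sit) in the series.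

Going on to compound 4 (`C#Cc1ccc2c(C(=O)Nc3cccc(F)c3)cc(=O)[nH]c2c1`) the change is ethynyl in place of 4-aminophenyl on an aromatic carbon and reads as ethynyl in place of 4-aminophenyl on an aromatic carbon. Among the measured compounds shown here, three measured steps bear on it (a step that the two limits leave unreadable from compound 1 to compound 2) and (a step that the two limits leave unreadable from compound 1 to compound 3) and (a step that the two limits leave unreadable from compound 2 to compound 3) and none has a readable size, so neither size nor direction carries over to compound 4 and no step beyond the scatter is expected in this assay for now. The expected move is (a number no higher from compound 3 to compound 4 (the limit leaves the size open)) and it is an estimate only. For compound 4 the estimate is 20000 nM with an expected range from 7000 nM to 40000 nM in this series.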

Compound 4, half-maximal inhibitory concentration: 9500 nM
The estimate for compound 4 lay 2.1-fold (0.32 log units) above the measured number, within the range that was stated.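

In this assay, among the compounds shown here, this position on the shared core gives a readable change for the first time: ethynyl in place of an aromatic ring brings an at least 2.1-fold lower number from compound 3 to compound 4 (0.32 log units; beyond the scatter) and an at least 2.1-fold lower number from compound 2 to compound 4 (0.32 log units; beyond the scatter) and an at least 2.1-fold lower number from compound 1 to compound 4 (0.32 log units; beyond the scatter). The steps among compound 1, compound 2 and compound 3 cannot be read, so changes on the phenyl ring itself say nothing yet. Compound 4, with no ring on this aromatic carbon, is the only one of the four with a number, and the other three share one limit: the limit of > 20000 nM in this assay, at which 3 of the 4 values shown sit.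

Whether the change follows the triple bond or the loss of the ring stays open, as the compounds shown do not separate the two. On these data alone, an ethyl chain or a nitrile on this carbon would bear on that question, and the true size of all three steps also remains unknown.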